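The source may hold more compounds than are shown below. What is called first, only, known or untested is meant among the compounds shown, and "the series" means these compounds.

For the measured compounds named here, in a functional assay on MDA-MB-231 cells (Homo sapiens) for cytotoxicity, read by MTT assay, with a stated time of 48 h (on this read-out higher numbers stand for weaker inhibition and lower numbers for stronger inhibition), compound 1 `C=C1CC[C@@H]2[C@](C)(COC(=O)CC)[C@H](OC(=O)CC)CC[C@@]2(C)[C@@H]1CCc1ccoc1` gives 40400 nM and compound 2 `C=C1[C@H](O)C[C@@H]2[C@](C)(COC(=O)CC)[C@H](OC(=O)CC)CC[C@@]2(C)[C@@H]1CCc1ccoc1` gives 40900 nM as its only measured neighbour, so the two stand level within the scatter and compound 1 holds no clear rank. The change to compound 3 `C=C1CC[C@@H]2[C@](C)(COC(=O)CC)[C@H](OC(=O)CC)CC[C@@]2(C)[C@@H]1CC(OC(=O)CC)c1ccoc1`, still unmeasured, is propanoyloxy in place of hydrogen on a saturated chain carbon bound to an aromatic carbon and a saturated chain carbon with propanoyloxy in place of hydrogen on a saturated chain carbon bound to an aromatic carbon and a saturated chain carbon. Going by the values given here, the one measured step, a 1.0-fold higher number from compound 1 to compound 2 (0.01 log units; within the scatter) when hydroxy replaces hydrogen on a saturated ring carbon, bears on this only loosely. Among the compounds with values here, it shows a different group on a ring carbon, and no measured compound carries propanoyloxy on that chain carbon. With so little evidence, no step beyond the scatter is expected in this assay and no direction can be given. The estimated step is a 1.1-fold lower number from compound 1 to compound 3 (0.03 log units; within the scatter) and remains only a working expectation. For compound 3 the estimate is 38000 nM with an expected range from 15000 nM to 95000 nM on repeated measurement.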

Compound 3, half-maximal inhibitory concentration: > 100000 nM
Compound 3 gave a limit, no number (the forecaster's own chance of this, stated with the estimate: 15%); middle value at least 2.6-fold (0.42 log units) from the limit.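

In this assay, the saturated chain carbon bound to an aromatic carbon and a saturated chain carbon is where the first step beyond the scatter appears among these compounds: putting propanoyloxy in place of hydrogen there gives an at least 2.4-fold higher number from compound 1 to compound 3 (0.39 log units; beyond the scatter), toward weaker inhibition. Compound 3 gives > 100000 nM, which is a limit of the assay and not a number. The step is therefore a minimum and its full size stays unknown: the limit of > 100000 nM in this assay, at which 1 of the 3 values shown sits.

The compounds shown cannot tell whether this weakening belongs to propanoyloxy itself or would follow any group on this carbon. A hydroxy, an acetoxy or an amine at this place would help to separate the two, and none of these is among the compounds shown.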